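The source may report more compounds than this note shows. Statements on the series, on what has been measured and on what is new or still open speak of the compounds shown alone.

Compound 2 `COc1cccc(NC(=O)CN2C/C(=N/N(C)C)NC[C@@H](Cc3cc(Cl)ccc3OC)C2=O)c1` stands highest of the two numbers recorded in an assay on isolated protein for inhibition of kallikrein-7 (Homo sapiens), read by fluorescence, with stated times of 10 min and 30 min (a higher number here means a weaker inhibitor, a lower number a stronger inhibitor), where compound 2 gives 2700 nM. Its nearest neighbour is compound 1 `COc1ccc(Cl)cc1C[C@@H]1CN/C(=N\N(C)C)CN(CC(=O)Nc2cccc(C(=O)N(C)C)c2)C1=O`; in this assay compound 1 gives 2500 nM, so the two are separated only by a 1.1-fold higher number from compound 1 to compound 2 (0.03 log units; within the scatter), a step within the scatter. Compound 3 `COc1ccc(Cl)cc1C[C@@H]1CN/C(=N\N(C)C)CN(CC(=O)Nc2cccc(-c3ccsc3)c2)C1=O` differs from compound 2 by thiophen-3-yl in place of methoxy on an aromatic carbon, sitting on an aromatic carbon meta to a large group. Within the data shown here, the single measured step bears on this only in that it altered the same position, swapping dimethylcarbamoyl for methoxy without moving the number beyond the scatter. Among the measured compounds shown here, no measured step introduces a five-membered aromatic ring at this place, so the expectation rests on that one neighbouring result alone. The step from compound 2 to compound 3 is therefore expected to be a 1.1-fold lower number from compound 2 to compound 3 (0.03 log units; within the scatter), none beyond the scatter. Compound 3 is estimated at 2500 nM, with a range from 900 nM to 7000 nM.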

Compound 3, half-maximal inhibitory concentration: 1500 nM
Compound 3: the middle estimate sits 1.7-fold (0.22 log units) above what was measured; low and high end bracket the measured number.
By their numbers in this assay, from the lowest: compounds 3, 1 and 2 (each within the scatter of the next).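

With thiophen-3-yl, this place on the aromatic ring, meta to a large group, now carries a five-membered aromatic ring, and the number still does not leave the scatter: in this assay the change from methoxy gives a 1.8-fold lower number from compound 2 to compound 3 (0.26 log units; within the scatter) and the change from dimethylcarbamoyl gives a 1.7-fold lower number from compound 1 to compound 3 (0.22 log units; within the scatter) at the same place. The three compounds thus show that a ring of 5 heavy atoms and a methoxy of 2 heavy atoms read alike here, so neither the added ring nor the size of the group has yet produced a step beyond the scatter. Nothing available explains why these groups read alike.

Going by these compounds, whether an amine, a carboxylic acid or a longer chain at this place would produce a step beyond the scatter remains open. Also open, on these data alone, is whether thiophen-2-yl or a phenyl ring would read as thiophen-3-yl does here.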